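Triazole series: chloro to methyl swap on compound 3

This account rests on a few compounds, and the source may have more. Where it says the series, first, only, none or still open, it means among the compounds named here.

Compound 3 `CCCC[C@@H](CCn1cncn1)c1ccc(Cl)cc1` gives 17 ug/mL in an ADME assay on HEp-2 cells (Homo sapiens) for cytotoxicity, read by MTT assay, with a stated time of 3 days (on this read-out lower numbers stand for higher toxicity in this test and higher numbers for lower toxicity in this test), the lowest of the three numbers in hand. Compound 1 `CC[C@@H](CCn1cncn1)c1ccc(Cl)cc1` gives 55.1 ug/mL and compound 2 `CCC[C@@H](CCn1cncn1)c1ccc(C)cc1` gives 71.3 ug/mL. For the measured compounds named here, the only single-point step available, a 3.2-fold lower number from compound 1 to compound 3 (0.51 log units; beyond the scatter), concerns the chain rather than the ring and so does not bear directly on the present change. Compound 4 `CCCC[C@@H](CCn1cncn1)c1ccc(C)cc1` differs from compound 3 by methyl in place of chloro on an aromatic carbon. Compound 1 and compound 2 differ in both chain and ring substituent, so their values cannot separate the two; they show only numbers close to each other. The step of a 1.4-fold higher number from compound 3 to compound 4 (0.15 log units; within the scatter) is therefore expected to be small. Compound 4 is expected at about 24 ug/mL in this assay, with an estimated range from 11 ug/mL to 55 ug/mL.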

Compound 4, half-maximal cytotoxic concentration: 60.7 ug/mL
Compound 4: middle estimate off by 2.5-fold (0.40 log units), on the low side; the measured number lies above the stated range.
By their numbers in this assay, from the lowest: compound 3; then compounds 1, 4 and 2 (each within the scatter of the next).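

In this assay, the ring carbon para to a large group proves sensitive: methyl in place of chloro gives a 3.6-fold higher number from compound 3 to compound 4 (0.55 log units; beyond the scatter). Methyl in place of hydrogen on the chain, with methyl on the ring, gives only a 1.2-fold lower number from compound 2 to compound 4 (0.07 log units; within the scatter), so among these compounds the low number of compound 3 appears only with chloro on the ring and the chain it shares with compound 4. Nothing available gives a cause for the step from chloro to methyl. From the compounds shown here alone, whether fluoro or methoxy at this ring position behaves like chloro or like methyl remains open. So does the effect of a longer chain on either ring.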